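The compounds below may be only part of what the source reports. "The series", "measured", "known", "first", "only" and "open" are said of these compounds alone.

Working notes on the series.

The set so far holds three compounds measured in an assay on HEK293 cells for agonist activity at transient receptor potential cation channel subfamily M member 8 (Homo sapiens), read by fluorescence and calcium flux, with a stated time of 15 min; on this read-out higher numbers stand for an effect only at larger amounts of compound and lower numbers for an effect already at smaller amounts. Compound 1, `CCN(Cc1ccco1)C(=O)COc1ccc(C)cc1`, gives 489 nM. Compound 2, `CCN(Cc1cccs1)C(=O)COc1ccc2c(c1)COC2`, gives 61 nM. Compound 3, `CCCc1ccc(OCC(=O)N(CC)Cc2cccs2)cc1`, gives 1810 nM. Within these three numbers compound 1 stands second highest: compound 3 sits a good way higher, beyond the scatter, and compound 2 sits well lower, again beyond the scatter. For the measured compounds named here, no two measured compounds differ in only one place, so no single change has yet been read in isolation; compound 2 and compound 3 share a thiophene-bearing part and differ elsewhere, and their two values simply show a wide spread.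

The next compound, compound 4, is `CCN(Cc1cncs1)C(=O)COc1ccc(C)cc1`. It is compound 1 with 1,3-thiazol-5-yl in place of furan-2-yl on a saturated chain carbon bound to an amide-type nitrogen. Nothing measured here tests a heteroaryl swap on its own, so the expectation rests on compound 1 alone. The step of a 1.4-fold higher number from compound 1 to compound 4 (0.16 log units; within the scatter) is expected to be small, most likely a modest move toward a higher number, and it may well sit inside the scatter. Because compound 1 gives 489 nM, compound 4 is estimated at 700 nM, with a range from 250 nM to 2000 nM.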

Compound 4, half-maximal effective concentration: 1100 nM
Estimate against measurement, compound 4: 1.6-fold (0.20 log units) below, and the stated range covers the measured number.
By their numbers in this assay, from the lowest: compound 2; then compound 1; then compounds 4 and 3 (each within the scatter of the next).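

In this assay, for the compounds shown here, this place, on a saturated chain carbon bound to an amide-type nitrogen, gives the first single change that can be read: 1,3-thiazol-5-yl in place of furan-2-yl yields a 2.2-fold higher number from compound 1 to compound 4 (0.35 log units; beyond the scatter) and the step is modest. The number therefore responds to an exchange between two five-membered aromatic rings of equal heavy-atom count, with the rest of compound 1 held constant and with the entering ring carrying one more hetero atom and one more hydrogen-bond acceptor by count. Nothing available here accounts for the step, which stands only as an observed difference between one pair of compounds.

The two rings differ in more than one atom, so the pair does not separate the contributions of the sulfur, the ring nitrogen and the point of attachment. Going by these compounds, it also remains open how a phenyl or pyridin-3-yl ring would read at this place on the core of compound 1, and whether the same exchange would give a similar step on the cores of compound 2 and compound 3.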